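The source may report more compounds than this note shows. Statements on the series, on what has been measured and on what is new or still open speak of the compounds shown alone.

Measured compounds:
compound 1, `NS(=O)(=O)c1ccc(CNc2nc(Nc3cccc(NC(=O)N4CCCC4)c3)ncc2Br)cc1` — > 10000 nM
compound 2, `O=C(NCCCNc1nc(Nc2cccc(NC(=O)N3CCCC3)c2)ncc1Br)C1CCC1` — 4.47 nM

Among the measured compounds shown here, in an assay on HEK293 cells for displacement of a labelled ligand from serine/threonine-protein kinase 17A (Homo sapiens), read by NanoBRET (a lower number here means a stronger inhibitor, a higher number a weaker inhibitor), compound 2 gives the only number, 4.47 nM. For compound 1 the result is a limit, > 10000 nM, as the limit of > 10000 nM in this assay, at which 1 of the 2 values shown sits, records. For the measured compounds named here, the one measured step, an at least 2200-fold lower number from compound 1 to compound 2 (3.34 log units; beyond the scatter), concerns a different part of the molecule. Compound 3, `O=C(NCCCNc1nc(Nc2cccc(NC(=O)N3CCCC3)c2)ncc1C1CC1)C1CCC1`, differs from compound 2 by cyclopropyl in place of bromo on an aromatic carbon. Going by the values given here, no measured step touches this position, so the expectation rests on compound 2 alone: a change in this assay not clearly beyond the scatter, a 1.8-fold higher number from compound 2 to compound 3 (0.25 log units; within the scatter). Compound 3 is therefore estimated at 8 nM, between 2 nM and 40 nM.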

Compound 3, half-maximal inhibitory concentration: 58.2 nM
Estimate against measurement, compound 3: 7.3-fold (0.86 log units) below; the whole stated range lies below it.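

This position is not indifferent in this assay: the change of a single group, cyclopropyl in place of bromo on an aromatic carbon, gives a 13-fold higher number from compound 2 to compound 3 (1.11 log units; beyond the scatter) as a large step. The earlier compounds shown here showed only the effect of the chain, so the substituent ortho to a large group and para to a large group now also counts. Nothing shown gives a reason for this step.

On these data alone, whether chloro, methyl or a nitrile here would stay close to bromo remains open. As far as these compounds go, it is also open whether the same step holds on a longer chain.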